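Removing the Methoxy: From Compound 3 to Compound 4

The source may report more compounds than this note shows. Statements on the series, on what has been measured and on what is new or still open speak of the compounds shown alone.

Compound 3 `COc1ccc(N/C=N/C2=C(C#N)C3C(N4CCCC4)CCCCN3C(=O)N2c2ccccc2)cc1` gives 20.6% in a functional assay on the whole organism (strain albino) for inhibition, with Rattus norvegicus as the target, read by paw edema, with a stated time of 1 h, at a dose of 20 mmol/kg by the intraperitoneal route (a lower number here means less inhibition, a higher number more inhibition at the dose given (going by the name of the read-out)), and stands lowest of the three numbers shown; its gap to compound 1 lies within the scatter, its gap to compound 2 beyond it. Compound 1 `N#CC1=C(NCN2CCCC2)N(c2ccccc2)C(=O)N2CCCCC(N3CCCC3)C12` gives 22.9% and compound 2 `N#CC1=C(/N=C/Nc2ccc([N+](=O)[O-])cc2)N(c2ccccc2)C(=O)N2CCCCC(N3CCCC3)C12` gives 32.1% in this assay. The step of a number 2.3 percentage points lower from compound 1 to compound 3 (within the scatter) and the step of a number 9.2 percentage points higher from compound 1 to compound 2 (within the scatter) are within the scatter, while the step of a number 11.5 percentage points lower from compound 2 to compound 3 (beyond the scatter) is modest. Compound 4 `N#CC1=C(/N=C/Nc2ccccc2)N(c2ccccc2)C(=O)N2CCCCC(N3CCCC3)C12` differs from compound 3 by hydrogen in place of methoxy on an aromatic carbon. Going by the values given here, only the nitro-to-methoxy step touches this aromatic carbon, and no measured step removes a methoxy, so the change for compound 4 is expected to be a number 4.4 percentage points higher from compound 3 to compound 4 (within the scatter), not beyond the scatter. Compound 4 is expected to give 25%, within 14% to 36%.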

Compound 4, a percentage reported as inhibition, in the whole organism at one dose (the size of the read-out at that dose, not a potency): 35.2%
The estimate for compound 4 lay 10.2 percentage points below the measured number; low and high end bracket the measured number.
By their numbers in this assay, from the lowest: compounds 3, 1, 2 and 4 (each within the scatter of the next, the first and the last beyond it).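

In this assay, hydrogen in place of methoxy gives a number 14.6 percentage points higher from compound 3 to compound 4 (beyond the scatter), while hydrogen in place of nitro gives a number 3.1 percentage points higher from compound 2 to compound 4 (within the scatter), so on this aromatic carbon only methoxy, of the two groups, separates from hydrogen. The unsubstituted compound also separates from the group carried by compound 1, with a number 12.3 percentage points higher from compound 1 to compound 4 (beyond the scatter), which neither substituted compound did. Nothing available explains these steps. As far as these compounds go, whether an amine, a chlorine or a longer alkoxy chain on this carbon would read with methoxy or with hydrogen remains open.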